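Mirror-Image Ester: Little Expected to Change

The source may hold more compounds than are shown below. What is called first, only, known or untested is meant among the compounds shown, and "the series" means these compounds.

Compound 1, `CC(C)c1noc(N2CCN(C(=O)[C@@H]3CCCN(S(=O)(=O)c4ccc(S(=O)(=O)C(C)C)cc4)C3)CC2)n1`: 30 nM
Compound 2, `CCOC(=O)[C@H]1CCN(S(=O)(=O)c2ccc(S(=O)(=O)N(CC)CC)cc2)C1`: > 10000 nM

Both compounds were tested in a functional assay on MIA PaCa-2 cells (Homo sapiens) for inhibition, read by MTT assay, with a stated time of 3 days; on this read-out lower numbers stand for stronger inhibition and higher numbers for weaker inhibition. Compound 1 sits at the active end of the two numbers shown. Compound 2 stands at the other end: in this assay compound 2 reaches only > 10000 nM, which is a limit of the assay rather than a measured number (the limit of > 10000 nM in this assay, at which 1 of the 2 values shown sits). Compound 3, `CCOC(=O)[C@@H]1CCN(S(=O)(=O)c2ccc(S(=O)(=O)N(CC)CC)cc2)C1`, is its mirror image: the two compounds have the same atoms and bonds and differ only in configuration as drawn: 1 of 1 stereo elements differ; a stereocentre at a saturated ring carbon is drawn S in compound 2 and R in compound 3. Among the compounds with values here, no measured step joins two compounds here. With compound 2 sitting at the limit, the step that the limit leaves unreadable from compound 2 to compound 3 is expected to show no change beyond scatter. Compound 3 is estimated at 12000 nM, between 3000 nM and 40000 nM.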

Compound 3, half-maximal inhibitory concentration: 1500 nM
For compound 3 the middle estimate is 8.0-fold (0.90 log units) above the measured one; measured number outside the range, below it.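

In this assay, the stereocentre at the saturated ring carbon clearly matters: drawing it R rather than S gives an at least 6.6-fold lower number from compound 2 to compound 3 (0.82 log units; beyond the scatter). The earlier compounds offered no measured pair, so this is the first readable step, and it can be traced to this stereocentre alone: the fact that compounds 2 and 3 differ only in the configuration as drawn The value of compound 2 is a limit of the assay: the limit of > 10000 nM in this assay, at which 1 of the 3 values shown sits.

As far as these compounds go, whether the R form keeps its edge with a carboxylic acid or an amide in place of the ethyl ester remains open. So does whether configuration at this carbon matters equally in the core of compound 1.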